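A few compounds are considered here, and "the series" means these few. Any claim that something is new, unique, unknown or untested is made for them only; others in the source may bear on it.

Measured so far in a functional assay on HeLa cells (Homo sapiens) for inhibition, read by trypan blue exclusion, with a stated time of 72 h; a lower number here means a stronger inhibitor of growth, a higher number a weaker inhibitor of growth:
- compound 1 `CC/C(=C(\c1ccccc1)c1ccc(NC(=O)C(C)C)cc1)c1ccccc1`: > 30000 nM (a limit)
- compound 2 `CC/C(=C(/c1ccccc1)c1ccc(NC(=O)C(C)C)cc1)c1ccccc1`: 28100 nM
- compound 3 `CC/C(=C(/c1ccccc1)c1ccc(NC(=O)C(C)C)cc1)c1ccc(Cl)cc1Cl`: 8200 nM

Compound 1 gives only a limit, > 30000 nM, and not a number. Of the two actual numbers, compound 2 has the higher, 28100 nM, and compound 3 is its nearest neighbour.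

The next compound is compound 4 `CC/C(=C(/c1ccc(O)cc1)c1ccc(NC(=O)C(C)C)cc1)c1ccccc1`, which differs from compound 2 by hydroxy in place of hydrogen on an aromatic carbon: phenyl to 4-hydroxyphenyl. For the measured compounds named here, two measured steps bear on this. The first shows an at least 1.0-fold lower number from compound 1 to compound 2 (0.02 log units; that floor lies within the scatter); it reflects the fact that compounds 1 and 2 differ only in the configuration as drawn and (the limit of > 30000 nM in this assay, at which 1 of the 3 values shown sits), and gives no guide to a new substituent. The second shows a 3.4-fold lower number from compound 2 to compound 3 (0.53 log units; beyond the scatter). It is the only measured substitution on a phenyl, though it involves a different group on a different phenyl. Resting on that single step, a modest move to a lower number is expected in this assay, with wide uncertainty. The estimated change is a 2.6-fold lower number from compound 2 to compound 4 (0.41 log units; beyond the scatter). For compound 4 the expected value is 11000 nM, with an estimated range of 3500 nM to 30000 nM.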

Compound 4, concentration for 50% growth inhibition: 9900 nM
Compound 4: the middle estimate sits 1.1-fold (0.05 log units) above what was measured; low and high end bracket the measured number.
By their numbers in this assay, from the lowest: compounds 3 and 4 (each within the scatter of the next); then compound 2. At a limit, above all of these: compound 1.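

In this assay, for the compounds shown here, this is the first measured change on this phenyl: hydroxy in place of hydrogen, on an aromatic carbon para to a large group, gives a 2.8-fold lower number from compound 2 to compound 4 (0.45 log units; beyond the scatter) and is a modest step. Until now the only substitution with a readable step was the 2,4-dichlorophenyl of compound 3, on a different phenyl, so this position now has its own measured step and a substituent here is compatible with growth inhibition. Nothing shown gives a cause for this step.

Still open, as far as these compounds go, is whether a methoxy, an amine or a carboxylic acid at the same place would give a number like that of compound 4, which would show whether the step is specific to hydroxy. Also open, from the compounds shown here alone, is how this hydroxy combines with the 2,4-dichlorophenyl of compound 3.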